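Nitro in place of methoxy on the shared core

A few compounds are considered here, and "the series" means these few. Any claim that something is new, unique, unknown or untested is made for them only; others in the source may bear on it.

In a functional assay on MCF7 cells (Homo sapiens) for cytotoxicity, read by MTT assay, with a stated time of 48 h (a higher number here means a weaker inhibitor, a lower number a stronger inhibitor), compound 3 (`COc1ccc2c(c1)nc(/C=C/C(=O)/C=C/c1ccc(OC)c(O)c1)n2C`) gives 3700 nM and stands level with compound 1 (`COc1cc(/C=C/C(=O)/C=C/c2nc3cc([N+](=O)[O-])ccc3n2C)ccc1O`) at 3700 nM while compound 2 (`COc1ccc(/C=C/C(=O)/C=C/c2nc3ccccc3n2C)cc1O`) gives 3600 nM within the scatter of compound 3. The move to compound 4 (`COc1ccc(/C=C/C(=O)/C=C/c2nc3cc([N+](=O)[O-])ccc3n2C)cc1O`) is nitro in place of methoxy on an aromatic carbon with nitro in place of methoxy on an aromatic carbon. Among the compounds with values here, the one measured step at this carbon is a 1.0-fold higher number from compound 2 to compound 3 (0.01 log units; within the scatter) and lies within the scatter. Differing elsewhere from compound 4 but also carrying nitro there, compound 1 gives 3700 nM as noted. In this assay the expected step is no change at the digits printed from compound 3 to compound 4 (within the scatter) with nothing beyond the scatter foreseen. Compound 4 is estimated at 3700 nM with an expected range from 1900 nM to 7200 nM in this series.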

Compound 4, half-maximal inhibitory concentration: 4800 nM
Beside the measured number, compound 4's estimate is 1.3-fold (0.11 log units) below it, and the stated range covers the measured number.
By their numbers in this assay, from the lowest: compounds 2, 1, 3 and 4 (each within the scatter of the next).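

In this assay nitro in place of methoxy on this aromatic carbon gives a 1.3-fold higher number from compound 3 to compound 4 (0.11 log units; within the scatter) and nitro in place of hydrogen gives a 1.3-fold higher number from compound 2 to compound 4 (0.12 log units; within the scatter) so hydrogen, methoxy and nitro here read alike within the scatter. With nitro held on this carbon, 3-hydroxy-4-methoxyphenyl in place of 4-hydroxy-3-methoxyphenyl gives a 1.3-fold higher number from compound 1 to compound 4 (0.11 log units; within the scatter) and this exchange on the chain also stays within the scatter. Open, going by these compounds, is what an amine or a carboxylic acid on this carbon would give, and whether the same phenyl exchange reads alike with methoxy here. No supporting data bear on why these numbers sit so close.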